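The source may report more compounds than this note shows. Statements on the series, on what has been measured and on what is new or still open speak of the compounds shown alone.

Compound 1 `COc1ccc(C(=O)/C=C/c2ccc(N(C)C)cc2)c2c1C=CC(C)(C)O2` carries dimethylamino on its outer aromatic ring, and in a functional assay on HepG2 cells (Homo sapiens) for antiproliferative activity, read by MTT assay, with a stated time of 24 h (a higher number here means a weaker inhibitor, a lower number a stronger inhibitor), compound 1 gives 730 nM. Compound 2 `COc1ccc(C(=O)/C=C/c2ccc(C(F)(F)F)cc2)c2c1C=CC(C)(C)O2` carries trifluoromethyl at that position instead. In this assay compound 2 reaches only a limit, > 10000 nM. Compound 3 `COc1ccc(C(=O)/C=C/c2cccc3ccccc23)c2c1C=CC(C)(C)O2` differs at the same end of the molecule. In this assay compound 3 likewise reaches only a limit, > 10000 nM. Compound 2 therefore stands at the limit of > 10000 nM in this assay, at which 2 of the 3 values shown sit, while compound 1 alone is given as a number.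

The unmeasured compound 4 `COc1ccc(C(=O)/C=C/c2ccc(O)cc2)c2c1C=CC(C)(C)O2` differs from compound 2 by hydroxy in place of trifluoromethyl on an aromatic carbon. Within the data shown here, one measured step bears on this change: an at least 13-fold higher number from compound 1 to compound 2 (1.13 log units; beyond the scatter). The change to compound 4 removes the same trifluoromethyl, so a move back toward a lower number is expected, though hydroxy is not dimethylamino and the lower end rests on compound 1 only. Compound 4 is therefore expected at an estimated 2500 nM, within a range of 600 nM to 10000 nM. This expectation amounts to an estimated at least 4.0-fold lower number from compound 2 to compound 4 (0.60 log units; beyond the scatter).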

Compound 4, half-maximal inhibitory concentration: > 10000 nM
Compound 4 gave a limit, no number (the forecaster's own chance of this, stated with the estimate: 30%); middle value at least 4.0-fold (0.60 log units) from the limit.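

Hydroxy in place of dimethylamino gives an at least 13-fold higher number from compound 1 to compound 4 (1.13 log units; beyond the scatter), so a second, very different replacement on the outer ring also loses the measurable activity of compound 1. Of the groups shown at this end of the molecule, only dimethylamino gives a number in this assay, and compound 2, compound 3 and compound 4 all go without one. Compound 4 is thus a further compound that reaches only the limit: the limit of > 10000 nM in this assay, at which 3 of the 4 values shown sit.

The step between compound 2 and compound 4 cannot be read, since both values are limits, so hydroxy and trifluoromethyl cannot be ordered against each other. As far as these compounds go, whether a plain amine or diethylamino at this position would also give a number, and so whether the activity depends on dimethylamino alone, stays open.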